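Moving a hydroxyl from the meta to the para position

The source may hold more compounds than are shown below. What is called first, only, known or untested is meant among the compounds shown, and "the series" means these compounds.

Measured compounds:
compound 1, `Oc1ccc(-c2cc(-c3cccc(C(F)(F)F)c3)cc(-c3cccc(O)c3)n2)cc1`, 9540 nM
compound 2, `Oc1ccc(-c2cc(-c3cccc(C(F)(F)F)c3)cc(-c3ccc(O)cc3)n2)cc1`, > 50000 nM
compound 3, `Oc1cccc(-c2cc(-c3ccc(OC(F)(F)F)cc3)cc(-c3ccccc3O)n2)c1`, 9410 nM

In a functional assay on HCT-15 cells (Homo sapiens) for inhibition (a lower number here means a stronger inhibitor, a higher number a weaker inhibitor), compound 1 gives 9540 nM. For compound 2 the assay reports only a limit, > 50000 nM; the value sits at the limit of > 50000 nM in this assay, at which 1 of the 3 values shown sits. The change from compound 1 to compound 2 is 4-hydroxyphenyl in place of 3-hydroxyphenyl on an aromatic carbon, and it gave an at least 5.2-fold higher number from compound 1 to compound 2 (0.71 log units; beyond the scatter). Compound 3 gives 9410 nM in this assay, a number close to that of compound 1; the difference between the cores of compound 1 and compound 3 is not broken down here. Compound 4, `Oc1ccc(-c2cc(-c3ccc(OC(F)(F)F)cc3)cc(-c3ccccc3O)n2)cc1`, is not yet measured. It differs from compound 3 by 4-hydroxyphenyl in place of 3-hydroxyphenyl on an aromatic carbon, the same kind of change as from compound 1 to compound 2, though here the place is meta to a 2-hydroxyphenyl group and meta to a large group rather than meta to a 3-(trifluoromethyl)phenyl group and a 4-hydroxyphenyl group. Given that the earlier step was an at least 5.2-fold higher number from compound 1 to compound 2 (0.71 log units; beyond the scatter), the expected step is a 4.3-fold higher number from compound 3 to compound 4 (0.63 log units; beyond the scatter). Compound 4 is estimated at 40000 nM, between 12000 nM and 150000 nM.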

Compound 4, half-maximal inhibitory concentration: > 50000 nM
Compound 4 was reported as a limit (the forecaster's own chance of this, stated with the estimate: 45%); at least 1.2-fold (0.09 log units) between middle value and limit.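

In this assay, 4-hydroxyphenyl in place of 3-hydroxyphenyl on the core of compound 3 gave an at least 5.3-fold higher number from compound 3 to compound 4 (0.72 log units; beyond the scatter). Compound 4 is reported only as a limit, > 50000 nM. The change therefore raised the number in the same direction on both cores, but this pair of cores does not establish a rule for the series, and the size of the two steps cannot be compared: the same change on two cores in this assay, an at least 5.2-fold higher number (0.71 log units; beyond the scatter) from compound 1 to compound 2 and an at least 5.3-fold higher number (0.72 log units; beyond the scatter) from compound 3 to compound 4; the limit leaves it open whether they differ

The compounds shown leave open how far the number would rise on either core if the limit did not apply. They also leave open whether the same step would appear with an amine or a carboxylic acid in place of the hydroxyl on that ring.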